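The source may hold more compounds than are shown below. What is called first, only, known or untested is meant among the compounds shown, and "the series" means these compounds.

Measured compounds:
Compound 1 `Cc1cc(CNC(C)(C)C)c(O)c(Nc2nc3cc(F)c(F)cc3n2Cc2ccc(C(F)(F)F)cc2)c1` — 90%
Compound 2 `CC(C)(C)NCc1cc(Cl)cc(Nc2nc3ccccc3n2Cc2ccc(C(F)(F)F)cc2)c1O` — 81%
Compound 3 `CCNCc1cc(Cl)cc(Nc2nc3cc(F)c(F)cc3[nH]2)c1O` — > 99%

The study turns on an ADME assay on microsomes from liver (Homo sapiens) for metabolic stability, read by LC-MS, with a stated time of 30 min, tested at 1 uM; a lower number here means that less of the compound is left, a higher number that more of the compound is left. Compound 1 gives 90% in this assay, the higher of the two numbers reported; compound 2 sits at 81%, a gap that lies within the scatter of the method, so the two cannot be ranked against each other. Compound 3 is a different case: its result of > 99% is a limit of the assay rather than a number (the limit of > 99% in this assay, at which 1 of the 3 values shown sits).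

Compound 4 `CC(C)(C)NCc1cc(Cl)cc(Nc2nc3cc(F)c(F)cc3n2Cc2ccc(C(F)(F)F)cc2)c1O` has not yet been measured. It differs from compound 1 in one place: chloro in place of methyl on an aromatic carbon. For the measured compounds named here, the other two compounds give no step that isolates this change, so the expectation rests on compound 1 alone. Compound 4 is expected to stay close to compound 1, a step of a number 2 percentage points higher from compound 1 to compound 4 (within the scatter) that is not expected to exceed the scatter. The estimate for compound 4 in this assay is 92%, with a range from 80% to 99%.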

Compound 4, percent of the compound remaining: 89%
Estimate against measurement, compound 4: 3 percentage points above, and the stated range covers the measured number.
By their numbers in this assay, from the lowest: compounds 2, 4 and 1 (each within the scatter of the next). At a limit, above all of these: compound 3.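

On the aromatic carbon para to a hydroxy group, chloro in place of methyl gives a number 1 percentage points lower from compound 1 to compound 4 (within the scatter) in this assay and so leaves the two compounds indistinguishable. This is the only step among the compounds shown that isolates a single change, and it shows that, with the rest of the structure held as in compound 1, this exchange has no effect that can be read beyond the scatter. Nothing measured here bears on the reason for this result.

On these data alone, whether a nitrile, a methoxy group or a plain hydrogen on the same carbon would also read the same remains open. Also open, as far as these compounds go, is whether the same exchange would give a similar result with a group other than the ((tert-butyl)amino)methyl group on the ring.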